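Cyano in place of ethynyl: a working note

The compounds below may be only part of what the source reports. "The series", "measured", "known", "first", "only" and "open" are said of these compounds alone.

Measured in a functional assay on L1210 cells (Mus musculus) for cytotoxicity; a higher number here means a weaker inhibitor, a lower number a stronger inhibitor:
- compound 1 `N#C[C@]1(CO)O[C@@H](n2ccc(N)nc2=O)C[C@@H]1O`: 330 nM
- compound 2 `C#C[C@]1(CO)O[C@@H](n2ccc(N)nc2=O)[C@H](O)[C@@H]1O`: > 350000 nM

Compound 2 gives > 350000 nM in this assay, which is a limit of the assay and not a number. Its position is therefore known only as the limit of > 350000 nM in this assay, at which 1 of the 2 values shown sits.

The next compound is compound 3 `N#C[C@]1(CO)O[C@@H](n2ccc(N)nc2=O)[C@H](O)[C@@H]1O`, which has cyano in place of ethynyl on a saturated ring carbon. For the measured compounds named here, no measured step covers this exchange. Going by the values given here, the only measured compound carrying cyano is compound 1, at 330 nM, so some gain in strength in this assay is expected, though compound 3 probably stays weak. The expected change is an at least 2.3-fold lower number from compound 2 to compound 3 (0.36 log units; beyond the scatter), a small shift towards stronger inhibition at most. For compound 3 the estimated value is 150000 nM, with an expected range of 10000 nM to 400000 nM.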

Compound 3, half-maximal inhibitory concentration: > 350000 nM
Compound 3 was reported as a limit (the forecaster's own chance of this, stated with the estimate: 55%); middle value at least 2.3-fold (0.36 log units) away from the limit.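

In this assay compound 3 gives > 350000 nM as a limit of the assay and not a number. The exchange of ethynyl for cyano therefore cannot be read, and where this change leaves the series is known only as: the limit of > 350000 nM in this assay, at which 2 of the 3 values shown sit. For the compounds shown here, the one readable step is an at least 1000-fold higher number from compound 1 to compound 3 (3.02 log units; beyond the scatter), for hydroxy in place of hydrogen on a saturated ring carbon, so with cyano held constant this single exchange separates a measurable value from the limit.

As far as these compounds go, it remains open whether cyano and ethynyl differ at all on the hydroxy-bearing core, and whether ethynyl on the core of compound 1 would give a measurable value. Also open, from the compounds shown here alone, is whether an aminomethyl group or a carboxylic acid in place of the cyano would bring the hydroxy-bearing core back into measurable range.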